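This account rests on a few compounds, and the source may have more. Where it says the series, first, only, none or still open, it means among the compounds named here.

Series notes, step from compound 1 to compound 4.

Compound 1 `CN1CCCN(CCn2ccc3ccc(Br)cc32)CC1` stands highest of the three numbers in an assay on HEK293 cells for binding affinity to 5-hydroxytryptamine receptor 7 (Homo sapiens), read by radioligand binding, tested at 1 uM (a lower number here means less inhibition, a higher number more inhibition at the concentration tested (going by the name of the read-out)), where compound 1 gives 93%. The nearest is compound 3 `CC(C)c1ccc2ccn(CCN3CCCN(C)CC3)c2c1`, which in this assay gives 72%; the furthest is compound 2 `CN1CCCN(CCn2ccc3ccc(O)cc32)CC1`, which in this assay gives 28%. Both measured departures from the bromo of compound 1 lower the read-out: a number 65 percentage points lower from compound 1 to compound 2 (beyond the scatter) and a number 21 percentage points lower from compound 1 to compound 3 (beyond the scatter). Between the two replacements, a number 44 percentage points higher from compound 2 to compound 3 (beyond the scatter).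

Compound 4 `CN1CCCN(CCn2ccc3ccc(-c4cccnc4)cc32)CC1` is not yet measured. Relative to compound 1 the change is pyridin-3-yl in place of bromo on an aromatic carbon. Among the measured compounds shown here, no measured step puts a pyridin-3-yl, or any aromatic ring, at this aromatic carbon, so the two steps from compound 1 bear only indirectly. Since every replacement of the bromo so far has lowered inhibition, by a modest amount for isopropyl and a large one for hydroxy, a modest downward step in this assay is expected for compound 4, estimated as a number 28 percentage points lower from compound 1 to compound 4 (beyond the scatter). The estimate for compound 4 in this assay is 65%, expected between 35% and 90%.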

Compound 4, a percentage reported as inhibition, at one concentration (the size of the read-out at that concentration, not a potency): 35%
For compound 4 the middle estimate is 30 percentage points above the measured one; measured number inside the range.
By their numbers in this assay, from the lowest: compounds 2 and 4 (each within the scatter of the next); then compound 3; then compound 1.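

In this assay, an aromatic ring on this aromatic carbon gives a large loss, a number 58 percentage points lower from compound 1 to compound 4 (beyond the scatter), and it leaves the read-out level with the hydroxy, a number 7 percentage points higher from compound 2 to compound 4 (within the scatter). Pyridin-3-yl also falls well short of isopropyl, a number 37 percentage points lower from compound 3 to compound 4 (beyond the scatter), so among these replacements of the bromo, the larger group with six heavy atoms does not keep more of the read-out. Nothing available on these compounds accounts for this drop.

Still open, as far as these compounds go, is whether the loss belongs to the aromatic ring as such or to its ring nitrogen, a question that phenyl at the same carbon would address. Equally open, from the compounds shown here alone, is whether a halogen such as chloro, or a small chain such as methyl, would stay closer to the bromo of compound 1.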